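One side chain swapped on a shared core

This account rests on a few compounds, and the source may have more. Where it says the series, first, only, none or still open, it means among the compounds named here.

Compound 1 `COc1c(OCc2cnoc2C)cc(O)c2c(=O)cc(-c3ccccc3)oc12` was tested in a functional assay on A549 cells (Homo sapiens) for cytotoxicity, read by MTT assay, with a stated time of 48 h; on this read-out higher numbers stand for weaker inhibition and lower numbers for stronger inhibition. In this assay compound 1 gives only a limit, > 100000 nM, so no single number is known for it. Compound 1 therefore sits at the limit of > 100000 nM in this assay, at which 1 of the 2 values shown sits. Compound 2 `CC(C)NCCCCOc1c(O)cc(O)c2c(=O)cc(-c3ccccc3)oc12` shares the core; in this assay compound 2 gives "not determined" (no result reported), so it offers nothing to compare with. Compound 3 `COc1c(OCCCN2CCNCC2)cc(O)c2c(=O)cc(-c3ccccc3)oc12` is the compound still to be measured, and it differs from compound 1 in one place: 2-(piperazin-1-yl)ethyl in place of 5-methyl-1,2-oxazol-4-yl on a saturated chain carbon bound to an oxygen on an aromatic ring. For the measured compounds named here, no measured step between two compounds of this set exists, so the size of this change cannot be read from any pair here. The step from the limit of compound 1 is expected to be at most a modest gain, an at least 1.4-fold lower number from compound 1 to compound 3 (0.15 log units; that floor lies within the scatter). Compound 3 is expected to give about 70000 nM in this assay, within 15000 nM to 300000 nM, with a real chance that only a limit is reported again.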

Compound 3, half-maximal inhibitory concentration: 10100 nM
Beside the measured number, compound 3's estimate is 6.9-fold (0.84 log units) above it, and the stated range ends above it.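

This position on the shared core is not indifferent in this assay: placing 2-(piperazin-1-yl)ethyl where 5-methyl-1,2-oxazol-4-yl stood brings an at least 9.9-fold lower number from compound 1 to compound 3 (0.99 log units; beyond the scatter). Cut one bond further out, the same change reads (5-methyl-1,2-oxazol-4-yl)methoxy to 3-(piperazin-1-yl)propoxy, so the aromatic ring and the chain change together in this one step. The step gives only a minimum size, since compound 1 is a limit and not a number: the limit of > 100000 nM in this assay, at which 1 of the 3 values shown sits.

A single step cannot separate the effect of the new ring from that of the longer chain. As far as these compounds go, whether a morpholine ring on the same propoxy chain, an open-chain dimethylamine, or a still longer chain carrying the piperazine would behave like the 3-(piperazin-1-yl)propoxy group stays open.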